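Methoxy Groups Return to the Amide Aryl Ring

A few compounds are considered here, and "the series" means these few. Any claim that something is new, unique, unknown or untested is made for them only; others in the source may bear on it.

Compound 1, `COc1ccc(C(=O)Nc2ccc(C(=O)/C=C/c3nc(C)c(C)nc3C)cc2)cc1OC`, in a functional assay on A549 cells (Homo sapiens) for antiproliferative activity, read by CCK-8 assay, with a stated time of 72 h (on this read-out higher numbers stand for weaker inhibition and lower numbers for stronger inhibition), gives 5060 nM. Compound 2, `Cc1nc(C)c(/C=C/C(=O)c2ccc(NC(=O)c3ccccc3)cc2)nc1C`, in this assay gives 7270 nM. Compound 3, `Cc1ccc(C(=O)Nc2ccc(C(=O)/C=C/c3nc(C)c(C)nc3C)cc2)cc1`, in this assay gives 9990 nM.

Compound 2 stands second highest of these three numbers, and all three sit within the usual scatter of one another: a 1.4-fold higher number from compound 1 to compound 2 (0.16 log units; within the scatter) and a 1.4-fold higher number from compound 2 to compound 3 (0.14 log units; within the scatter). Compound 4, `COc1cc(OC)cc(C(=O)Nc2ccc(C(=O)/C=C/c3nc(C)c(C)nc3C)cc2)c1`, is reached from compound 2 by a single change: 3,5-dimethoxyphenyl in place of phenyl on a carbonyl carbon. Going by the values given here, the step that bears most on this is the one from compound 1 to compound 2, where removing the 3,4-dimethoxyphenyl in favour of phenyl gave a 1.4-fold higher number from compound 1 to compound 2 (0.16 log units; within the scatter), a change too small to count. Compound 4 puts methoxy groups back, though as a 3,5-dimethoxyphenyl rather than the 3,4-dimethoxyphenyl of compound 1, so there is no direct measurement of this exact group. On that basis the step from compound 2 to compound 4 in this assay is expected to be small, leaning toward a lower number but likely within the scatter: a 1.3-fold lower number from compound 2 to compound 4 (0.12 log units; within the scatter). Compound 4 is therefore estimated at 5500 nM, with a range from 2500 nM to 12000 nM.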

Compound 4, half-maximal inhibitory concentration: 10200 nM
Compound 4: the middle estimate sits 1.9-fold (0.27 log units) below what was measured, and the stated range covers the measured number.
By their numbers in this assay, from the lowest: compounds 1, 2, 3 and 4 (each within the scatter of the next).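

Placing 3,5-dimethoxyphenyl on the carbonyl carbon in place of phenyl gives a 1.4-fold higher number from compound 2 to compound 4 (0.15 log units; within the scatter) in this assay, so adding these two methoxy groups to the bare ring produces no step that can be told from noise. The comparisons with the other two rings read the same way, with a 1.0-fold higher number from compound 3 to compound 4 (0.01 log units; within the scatter) and a 2.0-fold higher number from compound 1 to compound 4 (0.30 log units; within the scatter) as the result, so this group cannot be separated from 4-methylphenyl or from 3,4-dimethoxyphenyl on this read-out. Nothing further is available here to account for these numbers.

As far as these compounds go, what stays open is whether any group at this place can produce a step beyond the scatter. A ring carrying an amine or a carboxylic acid, or a saturated cyclohexyl ring in place of the phenyl, would put that question to a sharper test.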